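Trifluoromethyl to Chloro on the Aryl Ring of Compound 1

The source may report more compounds than this note shows. Statements on the series, on what has been measured and on what is new or still open speak of the compounds shown alone.

Compound 1 `CCC(C(=O)N1CCN(c2cccc(C(F)(F)F)c2)CC1)N1C(=O)CCC1=O` is the weaker of the two measured compounds. In a functional assay on the whole organism (strain Swiss) with Mus musculus as the target, in the maximal electroshock model, with a stated time of 1 h, at a dose of 100 mg/kg by the intraperitoneal route (on this read-out higher numbers stand for a stronger effect at the one dose given and lower numbers for a weaker effect), compound 1 gives 0%, the lowest of the two numbers shown. Its nearest neighbour, compound 2 `CC(C(=O)N1CCN(c2cccc(C(F)(F)F)c2)CC1)N1C(=O)CCC1=O`, gives 50% in this assay, and the step of a number 50 percentage points higher from compound 1 to compound 2 (beyond the scatter) comes with hydrogen in place of methyl on a saturated chain carbon, two bonds along the chain from an amide-type nitrogen in a ring and a carbonyl carbon.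

Compound 3 `CCC(C(=O)N1CCN(c2cccc(Cl)c2)CC1)N1C(=O)CCC1=O` differs from compound 1 only on the aromatic ring: chloro in place of trifluoromethyl on an aromatic carbon. Within the data shown here, no measured step touches this position; the one step available concerns the chain carbon and offers no guide to the aryl change. With compound 1 already at the floor of the read-out, the step of a number 10 percentage points higher from compound 1 to compound 3 (within the scatter) is expected to be small and, if anything, upward. Compound 3 is estimated to give 10% in this assay, within 0% to 40%.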

Compound 3, a percentage reported as activity, at one dose (the size of the read-out at that dose, not a potency): 0%
Compound 3: middle estimate off by 10 percentage points, on the high side; the measured number falls inside the stated range.
By their numbers in this assay, from the lowest: compounds 1 and 3 (each within the scatter of the next); then compound 2.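

Among these compounds, replacing trifluoromethyl with chloro on the aromatic carbon gives the first reading at this position: in this assay there is no change at the digits printed from compound 1 to compound 3 (within the scatter). On the core of compound 1, then, this swap of the aryl substituent does not lift the read-out off the floor, whereas the step on the chain carbon, a number 50 percentage points higher from compound 1 to compound 2 (beyond the scatter), does. Nothing available bears on why the aryl change leaves the read-out where it stands.

From the compounds shown here alone, since compound 1 already sits at the bottom of the read-out, a loss from this swap could not be seen here, so it remains open whether chloro would behave the same way on the core of compound 2, where there is room to fall. Also open, going by these compounds, is how a methoxy or a nitrile on that aromatic carbon would read.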